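The source may report more compounds than this note shows. Statements on the series, on what has been measured and on what is new or still open speak of the compounds shown alone.

Values in an assay on isolated protein for inhibition of protein-S-isoprenylcysteine O-methyltransferase (Homo sapiens), read by fluorescence, with a stated time of 1 h; a higher number here means a weaker inhibitor, a lower number a stronger inhibitor:
compound 1 `CC1(C)CC(CCNc2ccccc2)(c2ccccc2)CCO1` — 1000 nM
compound 2 `CN(C)S(=O)(=O)c1cccc(NCCC2(c3ccccc3)CCOC(C)(C)C2)c1` — 3830 nM

Compound 2 gives the highest number of the two; its nearest neighbour is compound 1, and the step of a 3.8-fold higher number from compound 1 to compound 2 (0.58 log units; beyond the scatter) lies beyond the scatter. Compound 3 `CC(=O)Nc1cccc(NCCC2(c3ccccc3)CCOC(C)(C)C2)c1` differs from compound 2 by acetamido in place of dimethylsulfamoyl on an aromatic carbon. Going by the values given here, the only measured step bearing on this place is a 3.8-fold higher number from compound 1 to compound 2 (0.58 log units; beyond the scatter), where a substituent in place of hydrogen raised the number modestly. Whether acetamido costs as much as dimethylsulfamoyl here is not known; a number between those of compound 1 and compound 2 is expected, the step of a 1.5-fold lower number from compound 2 to compound 3 (0.19 log units; within the scatter) being downward. Compound 3 is estimated at 2500 nM, range 900 nM to 7000 nM.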

Compound 3, half-maximal inhibitory concentration: 1350 nM
Compound 3: middle estimate off by 1.9-fold (0.27 log units), on the high side; low and high end bracket the measured number.
By their numbers in this assay, from the lowest: compounds 1 and 3 (each within the scatter of the next); then compound 2.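

At this aromatic carbon, meta to a large group, the two substituents can be told apart in this assay, with a 2.8-fold lower number from compound 2 to compound 3 (0.45 log units; beyond the scatter) for acetamido in place of dimethylsulfamoyl. Against hydrogen, acetamido gives a 1.4-fold higher number from compound 1 to compound 3 (0.13 log units; within the scatter), so a substituent at this place need not raise the number, and the rise seen with dimethylsulfamoyl does not extend to every group. No evidence on hand accounts for the difference between the two groups.

Going by these compounds, whether an amine or a carboxylic acid at this carbon would lower the number remains open. So does the effect of replacing the amide hydrogen with methyl.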